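A few compounds are considered here, and "the series" means these few. Any claim that something is new, unique, unknown or untested is made for them only; others in the source may bear on it.

Of the compounds shown here, three built on a shared core have been measured in a functional assay on MDA-MB-231 cells (Homo sapiens) for inhibition, read by sulforhodamine B assay, tested at 10 uM; on this read-out higher numbers stand for more inhibition at the one concentration tested (going by the name of the read-out) and lower numbers for less inhibition. Compound 1 `Cc1ccc(C(=O)N2N=C(c3ccc(N4CCN(C)CC4)cc3)CC2c2ccc(N(C)C)cc2)cc1` gives -0.7%. Compound 2 `CN1CCN(c2ccc(C3=NN(C(=O)/C=C/c4ccccc4)C(c4ccc(N(C)C)cc4)C3)cc2)CC1` gives 35.9%. Compound 3 `Cc1ccc(S(=O)(=O)N2N=C(c3ccc(N4CCN(C)CC4)cc3)CC2c2ccc(N(C)C)cc2)cc1` gives 10.7%, which places it second highest of the three: above compound 1, as shown by a number 11.4 percentage points higher from compound 1 to compound 3 (beyond the scatter), and below compound 2, as shown by a number 25.2 percentage points lower from compound 2 to compound 3 (beyond the scatter). The largest step among the measured compounds is a number 36.6 percentage points higher from compound 1 to compound 2 (beyond the scatter).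

Compound 4 `CN1CCN(c2ccc(C3=NN(S(=O)(=O)c4ccc(F)cc4)C(c4ccc(N(C)C)cc4)C3)cc2)CC1` is the compound not yet measured. It differs from compound 3 at one place: fluoro in place of methyl on an aromatic carbon. The change sits on an aromatic carbon of a six-membered aromatic ring of carbon only, para to a large group, within the (4-methylphenyl)sulfonyl group of compound 3.

Within the data shown here, none of the measured steps touches this part of the molecule; every one of them exchanges the whole group on the amine nitrogen in the ring, and the three measured compounds show only how much that group can shift the number. A one-atom exchange on the outer aromatic ring is therefore expected to move the number little, by a number 1.3 percentage points higher from compound 3 to compound 4 (within the scatter), which is within the scatter. Compound 4 is estimated at 12%, with a range from -2% to 28%.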

Compound 4, a percentage reported as inhibition, at one concentration (the size of the read-out at that concentration, not a potency): 15.7%
For compound 4 the middle estimate is 3.7 percentage points below the measured one, and the stated range covers the measured number.
By their numbers in this assay, from the lowest: compound 1; then compounds 3 and 4 (each within the scatter of the next); then compound 2.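

In this assay, among these compounds, this is the first look at the outer aromatic ring of the sulfonyl group, at the carbon para to a large group, and exchanging methyl for fluoro there gives a number 5 percentage points higher from compound 3 to compound 4 (within the scatter). Among the compounds shown here, at this place, then, the two groups cannot be told apart on this read-out, whereas the earlier steps showed only what happens when the whole group on the amine nitrogen in the ring is replaced. Such whole-group exchanges still read beyond the scatter with the fluoro compound, which gives a number 20.2 percentage points lower from compound 2 to compound 4 (beyond the scatter) and a number 16.4 percentage points higher from compound 1 to compound 4 (beyond the scatter), and nothing available offers an explanation for any of these numbers.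

On these data alone, only methyl and fluoro appear at this ring position, so it remains open how a methoxy group, an amine or a carboxylic acid would read at the same carbon. As far as these compounds go, it is also open whether the exchange of methyl for fluoro would read the same way on the 4-methylphenyl group of compound 1, where a carbonyl takes the place of the sulfonyl.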